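Swapping the Aryl Amine on a Shared Urea Core

A few compounds are considered here, and "the series" means these few. Any claim that something is new, unique, unknown or untested is made for them only; others in the source may bear on it.

Compound 1 `COc1ccc(F)cc1Nc1cc(NC(=O)Nc2c(Cl)cccc2Cl)ncn1`: 31.3%
Compound 2 `COc1ccc(Br)cc1Nc1cc(NC(=O)Nc2c(Cl)cccc2Cl)ncn1`: 33%

In a functional assay on NCI-H226 cells (Homo sapiens) for inhibition, read by MTT assay, with a stated time of 48 h, tested at 10 uM (a higher number here means more inhibition at the concentration tested (going by the name of the read-out), a lower number less inhibition), compound 2 gives 33%, and compound 1 gives 31.3%, two numbers whose gap falls within the scatter. Among the measured compounds shown here, the only measured step, a number 1.7 percentage points higher from compound 1 to compound 2 (within the scatter), exchanges one halogen for another and changes nothing beyond the scatter. Compound 3 `O=C(Nc1cc(Nc2ccc(F)c(Cl)c2)ncn1)Nc1c(Cl)cccc1Cl` departs from compound 2 in a larger way: 3-chloro-4-fluorophenyl in place of 5-bromo-2-methoxyphenyl on a nitrogen on an aromatic ring. For the measured compounds named here, no measured step covers such a change, so the expected step of a number 3 percentage points lower from compound 2 to compound 3 (within the scatter) is small, with wide uncertainty. Compound 3 is therefore estimated at 30%, between 10% and 52%.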

Compound 3, a percentage reported as inhibition, at one concentration (the size of the read-out at that concentration, not a potency): 47.3%
Estimate against measurement, compound 3: 17.3 percentage points below; low and high end bracket the measured number.
By their numbers in this assay, from the lowest: compounds 1 and 2 (each within the scatter of the next); then compound 3.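

Where the halogen exchange moved nothing beyond the scatter, replacing the whole aryl group on this nitrogen does: 3-chloro-4-fluorophenyl in place of 5-bromo-2-methoxyphenyl gives a number 14.3 percentage points higher from compound 2 to compound 3 (beyond the scatter), and in place of 5-fluoro-2-methoxyphenyl it gives a number 16 percentage points higher from compound 1 to compound 3 (beyond the scatter). This position can therefore shift the read-out, though both steps are modest. Nothing available explains the rise. The entering group differs from those leaving in its halogens and in lacking the methoxy, so the compounds shown cannot separate these changes. As far as these compounds go, how an amine or a carboxylic acid on this aromatic ring would fare also stays open.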